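The compounds below may be only part of what the source reports. "The series", "measured", "known", "first", "only" and "open" are said of these compounds alone.

In a functional assay on DU-145 cells (Homo sapiens) for cytotoxicity, read by sulforhodamine B assay, with a stated time of 3 days (on this read-out lower numbers stand for an effect already at smaller amounts and higher numbers for an effect only at larger amounts of compound), compound 1 (`CCOCc1c(C)coc1-c1ccc2c(c1OC)CCCC2(C)C`) gives 17.7 uM and compound 2 (`CCOc1c(-c2occ(C)c2CO)ccc2c1CCCC2(C)C`) gives 17.5 uM so the two values lie within the scatter of each other. Compound 3 (`COCc1c(C)coc1-c1ccc2c(c1OC)CCCC2(C)C`) has hydrogen in place of methyl on a saturated chain carbon bound to an oxygen on a saturated carbon, which reads as ethoxymethyl to methoxymethyl (hydrogen in place of methyl on a saturated chain carbon bound to an oxygen on a saturated carbon). Among the measured compounds shown here, no measured pair shows this change on its own. No shift beyond the scatter is expected in this assay in either direction. The expected step is a 1.1-fold higher number from compound 1 to compound 3 (0.05 log units; within the scatter) on this estimate. Compound 3 is estimated at 20 uM with an expected range from 10 uM to 40 uM as its bounds.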

Compound 3, concentration for half-maximal effect: 17.5 uM
Estimate against measurement, compound 3: 1.1-fold (0.06 log units) above, and the stated range covers the measured number.
By their numbers in this assay, from the lowest: compounds 2, 3 and 1 (each within the scatter of the next).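

Among the compounds shown here, the change from ethoxymethyl to methoxymethyl gives the first single-place reading: in this assay it amounts to a 1.0-fold lower number from compound 1 to compound 3 (0.00 log units; within the scatter). At this place, on a saturated chain carbon bound to an oxygen on a saturated carbon, the number therefore holds when methyl gives way to hydrogen. Nothing available explains this result.

The compounds shown leave open whether a longer chain such as butoxymethyl, or an amine or carboxylic acid in place of the ether, would move the number beyond the scatter.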